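Ester to Amide on Two Cores Against a Kinase

A few compounds are considered here, and "the series" means these few. Any claim that something is new, unique, unknown or untested is made for them only; others in the source may bear on it.

The study measures inhibition in an assay on isolated protein for inhibition of MAP kinase-interacting serine/threonine-protein kinase 1 (Homo sapiens), read by HTRF, in the presence of a further agent that is not named here; a higher number here means a weaker inhibitor, a lower number a stronger inhibitor. Compound 1 `COC(=O)c1oc2ccc(Nc3ncnc4ccc(Cl)nc34)cc2c1C` is one member of the set. In this assay compound 1 gives > 10000 nM, which is a limit of the assay and not a number. Compound 2 `COC(=O)c1cccc(C#Cc2ccccc2Nc2ncnc3ccc(Cl)nc23)c1` carries a different core; the difference between the two cores is not broken down here. In this assay compound 2 gives > 10000 nM, again only a limit. Compound 3 `CN(C)C(=O)c1cccc(C#Cc2ccccc2Nc2ncnc3ccc(Cl)nc23)c1` is made from compound 2 by dimethylamino in place of methoxy on a carbonyl carbon. In this assay compound 3 gives > 10000 nM, once more a limit. The resulting step that the two limits leave unreadable from compound 2 to compound 3 therefore cannot be read, because of the limit of > 10000 nM in this assay, at which 3 of the 3 values shown sit.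

Compound 4 `Cc1c(C(=O)N(C)C)oc2ccc(Nc3ncnc4ccc(Cl)nc34)cc12` has not been measured. It is made from compound 1 by dimethylamino in place of methoxy on a carbonyl carbon, the same change as that from compound 2 to compound 3, at a place described in the same words. With both ends of the earlier step sitting at the limit, the data carry no sign that this change recovers measurable inhibition on either core. For compound 4 a step that the limit leaves unreadable from compound 1 to compound 4 is expected in this assay, resting on the unreadable step that the two limits leave unreadable from compound 2 to compound 3. Compound 4 is thus estimated at 20000 nM in this assay, with a range from 7000 nM to 60000 nM, and most likely the assay will report only a limit for compound 4 as well.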

Compound 4, half-maximal inhibitory concentration: > 10000 nM
Compound 4: only a limit was reported (the forecaster's own chance of this, stated with the estimate: 85%); the middle value is on the limit's open side.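

In this assay compound 4 gives > 10000 nM, which is a limit and not a number. No step from compound 1 to compound 4 can be read, because neither end of the pair gives a number: the limit of > 10000 nM in this assay, at which 4 of the 4 values shown sit.

The compounds shown leave open whether dimethylamino in place of methoxy on a carbonyl carbon changes inhibition at all on either core, and what would bring inhibition into the measurable range.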